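The source may report more compounds than this note shows. Statements on the series, on what has been measured and on what is new or still open speak of the compounds shown alone.

Among the measured compounds shown here, compound 2 `Cc1ccc(-c2cc(-c3ccoc3)cc(-c3ccc(Cl)s3)n2)o1` gives the lower of the two numbers so far in an assay on isolated protein for inhibition of DNA topoisomerase 1 (Homo sapiens), with a stated time of 30 min, tested at 100 uM (on this read-out higher numbers stand for more inhibition at the one concentration tested (going by the name of the read-out) and lower numbers for less inhibition), with 13.2%, while compound 1 `Clc1ccc(-c2cc(-c3ccco3)cc(-c3ccc(Cl)s3)n2)cc1` gives 53.1%, a gap beyond the usual scatter. Compound 3 `Clc1ccc(-c2cc(-c3ccoc3)cc(-c3ccccc3Cl)n2)s1` has not yet been measured. It differs from compound 2 by 2-chlorophenyl in place of 5-methylfuran-2-yl on an aromatic carbon. For the measured compounds named here, no measured pair isolates this change, so its size is uncertain. Compound 3 does share a chlorophenyl group with compound 1, which gave 53.1%. The step of a number 21.8 percentage points higher from compound 2 to compound 3 (beyond the scatter) in this assay is therefore expected to be a moderate rise. Compound 3 is estimated at 35%, within 10% to 60%.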

Compound 3, a percentage reported as inhibition, at one concentration (the size of the read-out at that concentration, not a potency): 0%
Estimate against measurement, compound 3: 35 percentage points above; the measured number lies below the stated range.
By their numbers in this assay, from the lowest: compound 3; then compound 2; then compound 1.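

Placing 2-chlorophenyl in place of 5-methylfuran-2-yl, on the carbon next to the ring nitrogen, brings a number 13.2 percentage points lower from compound 2 to compound 3 (beyond the scatter) in this assay. This position is therefore not indifferent to the group it carries, and here the 2-chlorophenyl group offers no gain over 5-methylfuran-2-yl. Nothing available explains the fall. As far as these compounds go, it remains open whether the loss follows the chlorine or the carbon-only ring, which an unsubstituted phenyl group could separate. Also open, from the compounds shown here alone, is how an amine or a carboxylic acid would fare on this carbon.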